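A few compounds are considered here, and "the series" means these few. Any claim that something is new, unique, unknown or untested is made for them only; others in the source may bear on it.

Of the compounds shown here, two with a shared core have been measured in a physicochemical assay for lipophilicity; on this read-out lower numbers stand for lower lipophilicity and higher numbers for higher lipophilicity. Compound 1, `O=[N+]([O-])c1cc[n+]([O-])c2c([N+](=O)[O-])cccc12`, carries two nitro groups, and in this assay compound 1 gives 0.76. Compound 2, `CCCCCc1ccc2c(c1)c([N+](=O)[O-])cc[n+]2[O-]`, carries one nitro group and a pentyl chain, and in this assay compound 2 gives 3.26. Of the two numbers, compound 2 stands highest, and its gap to compound 1 lies beyond the usual scatter of repeated measurements. The two structures differ in more than one place, so the gap between them is only what the two values show.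

Compound 3, `Cc1ccc2c(c1)c([N+](=O)[O-])cc[n+]2[O-]`, has not yet been measured in this assay. It differs from compound 2 in one place: hydrogen in place of butyl on a saturated chain carbon bound to an aromatic carbon. Four heavy atoms of chain leave and nothing but a hydrogen enters. A step downward in this assay is expected, larger than the scatter. Compound 3 is expected to give 1.3, with a range from 0.8 to 1.8, which is estimated to be a step of a number 1.96 log units lower from compound 2 to compound 3 (beyond the scatter); this expectation rests on compound 2 giving 3.26 and on the chain it loses.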

Compound 3, partition coefficient: 1.24
The estimate for compound 3 lay 0.06 log units above the measured number; low and high end bracket the measured number.
By their numbers in this assay, from the lowest: compound 1; then compound 3; then compound 2.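

Compound 1 and compound 2 differ in more than one place, so their gap could not be tied to any single part of the structure. The new pair differs in one place only: in this assay, going from pentyl to methyl, with hydrogen in place of butyl on a saturated chain carbon bound to an aromatic carbon, comes with a step of a number 2.02 log units lower from compound 2 to compound 3 (beyond the scatter), while the nitro group and the shared core stay as they were. This shows that the read-out responds strongly to the length of the chain at this place, but nothing measured here explains why the number moves with the chain.

With only a methyl and a pentyl chain shown at this place, it remains open whether the numbers climb evenly through ethyl, propyl and butyl, level off, or continue upward with a longer chain such as octyl. Also open, as far as these compounds go, are what an amine or a carboxylic acid would give at this same place, and whether the same change would give a step of similar size on a core carrying a second nitro group, as in compound 1.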